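This account rests on a few compounds, and the source may have more. Where it says the series, first, only, none or still open, it means among the compounds named here.

Compound 1 `COc1ccc2c(OCC[C@@H]3NC(=O)N(C)CCCC/C=C\[C@@H]4C[C@@]4(C(=O)NS(=O)(=O)N(C)C)NC3=O)cc(-c3nc(C(C)C)cs3)nc2c1Cl` is tested in an ADME assay on cells (Homo sapiens) for activation (on this read-out lower numbers stand for higher toxicity in this test and higher numbers for lower toxicity in this test), where compound 1 gives 47800 nM. Among the three compounds measured so far this is the highest number. Compound 2 `COc1ccc2c(OCC[C@@H]3NC(=O)N(C)CCCC/C=C\[C@@H]4C[C@@]4(C(=O)NS(=O)(=O)C4(C)CC4)NC3=O)cc(-c3nc(C(C)C)cs3)nc2c1Br` gives 28300 nM, and that value sits within the usual scatter of the value of compound 1. Compound 3 `C#C[C@@H]1CCCN1S(=O)(=O)NC(=O)[C@@]12C[C@H]1/C=C\CCCCN(C)C(=O)N[C@@H](CCOc1cc(-c3nc(C(C)C)cs3)nc3c(Cl)c(OC)ccc13)C(=O)N2` gives 21200 nM, and the change there is a 2.3-fold lower number from compound 1 to compound 3 (0.35 log units; beyond the scatter).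

Compound 4 `COc1ccc2c(OCC[C@@H]3NC(=O)N(C)CCCC/C=C\[C@@H]4C[C@@]4(C(=O)NS(=O)(=O)C4CC4)NC3=O)cc(-c3nc(C(C)C)cs3)nc2c1Cl` differs from compound 1 in one place: cyclopropyl in place of dimethylamino on a sulfonyl sulfur. Going by the values given here, of the measured steps, only the one from compound 1 to compound 3 bears on this change directly, since it also swaps the dimethylamino group on the sulfonyl sulfur for a ring-bearing group, and it gave a modest lowering. Compound 2 also carries a ring on the sulfonyl sulfur, but it differs from compound 1 in a second place as well, so its value can only be taken as a loose hint. On this basis a modest lowering, close to the edge of the scatter, is expected in this assay, namely a 1.6-fold lower number from compound 1 to compound 4 (0.20 log units; within the scatter). Compound 4 is therefore estimated at 30000 nM, with a range from 13000 nM to 70000 nM.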

Compound 4, half-maximal cytotoxic concentration: 40400 nM
Estimate against measurement, compound 4: 1.3-fold (0.13 log units) below; low and high end bracket the measured number.
By their numbers in this assay, from the lowest: compounds 3, 2, 4 and 1 (each within the scatter of the next, the first and the last beyond it).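

In this assay, the change from dimethylamino to cyclopropyl on a sulfonyl sulfur stays within the usual scatter (a 1.2-fold lower number from compound 1 to compound 4 (0.07 log units; within the scatter)), so an open-chain nitrogen group and a carbon ring with matching heavy-atom counts are not told apart at this position. The 2-ethynylpyrrolidin-1-yl group of compound 3 is not clearly separated from cyclopropyl either (a 1.9-fold higher number from compound 3 to compound 4 (0.28 log units; within the scatter)), even though the step from dimethylamino to that group lies beyond the scatter (a 2.3-fold lower number from compound 1 to compound 3 (0.35 log units; beyond the scatter)). Thus, only the two most distant groups in this series can be told apart, and the data offer no measured explanation for these values.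

Still open, as far as these compounds go, is how the read-out would respond to a primary amine, a carboxylic acid or a longer alkyl chain on the sulfonyl sulfur. Compound 2 differs from compound 4 in two places, so its value cannot be credited to either change alone.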